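From Hydroxy to Nitro on an Aromatic Ring

This account rests on a few compounds, and the source may have more. Where it says the series, first, only, none or still open, it means among the compounds named here.

In a functional assay on U-937 cells (Homo sapiens) for antiproliferative activity, with a stated time of 48 h (on this read-out higher numbers stand for an effect only at larger amounts of compound and lower numbers for an effect already at smaller amounts), compound 1 `O=C(CCCCCCC(=O)Nc1ccc(O)cc1)NO` gives 6400 nM. This puts it level with compound 3 `O=C(CCCCCCC(=O)Nc1ccccc1Br)NO` at 6800 nM, as the two lie within the usual scatter, while compound 2 `O=C(CCCCCCC(=O)Nc1cccc(F)c1)NO` shows a clearly lower 500 nM.

Compound 4 `O=C(CCCCCCC(=O)Nc1ccc([N+](=O)[O-])cc1)NO` is still unmeasured. It has nitro in place of hydroxy on an aromatic carbon, para to a large group: nitro in place of hydroxy on an aromatic carbon. Going by the values given here, no measured pair shows this exact change, so the spread from compound 2 at 500 nM to compound 3 at 6800 nM is the only guide. The expected step is modest and towards a lower number: a 2.6-fold lower number from compound 1 to compound 4 (0.41 log units; beyond the scatter). For compound 4 the estimated value is 2500 nM, with an expected range from 600 nM to 8000 nM.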

Compound 4, half-maximal effective concentration: 22000 nM
Estimate against measurement, compound 4: 8.8-fold (0.94 log units) below; measured number above the stated range.
By their numbers in this assay, from the lowest: compound 2; then compounds 1 and 3 (each within the scatter of the next); then compound 4.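

At this place on the ring, para to a large group, putting nitro in place of hydroxy gives a 3.4-fold higher number from compound 1 to compound 4 (0.54 log units; beyond the scatter) in this assay. Going by these compounds alone, this is the first step here that changes one group at a single place, and it shows that the number responds to the group at this carbon, moving towards larger amounts of compound. Nothing available explains why the swap moves the number this way.

With only hydroxy and nitro compared at this carbon, one step sets no trend. As far as these compounds go, how an amine or a methoxy group would read at the same place remains open.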